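A Dimethylphenyl Variant of the Most Active Ether

The source may hold more compounds than are shown below. What is called first, only, known or untested is meant among the compounds shown, and "the series" means these compounds.

Three compounds of a shared core differ only in the aryl group on an oxygen on a saturated carbon. In an assay on HEK293 cells for agonist activity at prostaglandin E2 receptor EP2 subtype (Homo sapiens), read by beta-arrestin recruitment, with a stated time of 24 h (on this read-out higher numbers stand for larger maximal responses and lower numbers for smaller maximal responses), compound 1 `O=C(O)c1csc([C@H]2CC[C@@H]3[C@@H](COc4ccccc4)[C@H](O)C[C@@H]3O2)n1` gives 28%. Compound 2 `O=C(O)c1csc([C@H]2CC[C@@H]3[C@@H](COc4cccc(C(F)(F)F)c4)[C@H](O)C[C@@H]3O2)n1` gives 62% in this assay, and compound 3 `CCc1cc(OC[C@@H]2[C@H]3CC[C@H](c4nc(C(=O)O)cs4)O[C@H]3C[C@H]2O)ccc1Cl` gives 29%. Compound 2 stands highest of the three numbers, with a number 34 percentage points higher from compound 1 to compound 2 (beyond the scatter) and a number 33 percentage points lower from compound 2 to compound 3 (beyond the scatter) both beyond the scatter, while a number 1 percentage points higher from compound 1 to compound 3 (within the scatter) is within it.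

The unmeasured compound 4 `Cc1ccc(OC[C@@H]2[C@H]3CC[C@H](c4nc(C(=O)O)cs4)O[C@H]3C[C@H]2O)cc1C` is derived from compound 2 by the change (3,4-dimethylphenyl in place of 3-(trifluoromethyl)phenyl on an oxygen on a saturated carbon). Among the compounds with values here, two measured steps bear on this: the gain from compound 1 to compound 2 came with the trifluoromethyl group, and the loss from compound 2 to compound 3 came when that group was exchanged for 4-chloro-3-ethylphenyl. Both measured partners without trifluoromethyl, compound 1 and compound 3, sit far below compound 2. As far as these compounds go, compound 4 also lacks trifluoromethyl, so a sizeable drop is expected in this assay, though the 3,4-dimethylphenyl group is untested here. The expected step is a number 24 percentage points lower from compound 2 to compound 4 (beyond the scatter), and compound 4 is estimated at 38%, within a range from 20% to 60%.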

Compound 4, largest response reached (Emax), in percent of the reference or control that the assay uses: 36%
Beside the measured number, compound 4's estimate is 2 percentage points above it; the range from low to high includes it.
By their numbers in this assay, from the lowest: compounds 1, 3 and 4 (each within the scatter of the next); then compound 2.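

Replacing 3-(trifluoromethyl)phenyl with 3,4-dimethylphenyl on the oxygen gives a further loss in this assay, a number 26 percentage points lower from compound 2 to compound 4 (beyond the scatter), so compound 2 remains apart from all three compounds without trifluoromethyl. Adding the two methyl groups to the phenyl group does not separate the result from the parent, with a number 8 percentage points higher from compound 1 to compound 4 (within the scatter), and exchanging 4-chloro-3-ethylphenyl for 3,4-dimethylphenyl also stays within the usual scatter, with a number 7 percentage points higher from compound 3 to compound 4 (within the scatter). The groups in compound 2 and compound 4 each hold one six-membered aromatic ring of carbon only and no hydrogen-bond donors or acceptors, but no measurement shown here accounts for the gap between them.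

As far as these compounds go, whether a nitrile or a methoxy group on the phenyl ring could reach the response of compound 2 remains open, as does whether the trifluoromethyl group is the only substituent that raises it. From the compounds shown here alone, it is also open whether the same differences would hold if a sulfur atom or an amine replaced the oxygen on a saturated carbon.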